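The source may hold more compounds than are shown below. What is called first, only, known or untested is meant among the compounds shown, and "the series" means these compounds.

Compound 1 `O=C(CSc1snnc1-c1ccccc1)Nc1ccccc1Br`, in an ADME assay on MT4 cells (Homo sapiens) for cytotoxicity (on this read-out higher numbers stand for lower toxicity in this test and lower numbers for higher toxicity in this test), gives only a limit of the assay, > 307000 nM.
Compound 2 `O=C(CSc1snnc1-c1ccc(F)cc1F)Nc1ccccc1F`, in this assay, gives 148000 nM.

Within the data shown here, compound 2 thus stands on the only numbered value in this set; the other entry, that of compound 1, is the limit of > 307000 nM in this assay, at which 1 of the 2 values shown sits. Compound 3 `O=C(CSc1snnc1-c1ccc(F)cc1F)Nc1ccccc1Br` has not yet been measured. It differs from compound 2 by bromo in place of fluoro on an aromatic carbon. Among the measured compounds shown here, no measured step of the same kind is available, so the size of the step can only be guessed. Compound 1, which also carries the bromo group, returned only a limit, > 307000 nM, so a move toward lower toxicity is expected rather than the reverse. The step is estimated as a 1.7-fold higher number from compound 2 to compound 3 (0.23 log units; within the scatter), toward lower toxicity, possibly beyond the usual scatter. For compound 3 the estimate is 250000 nM, with a range from 100000 nM to 400000 nM, and a fair chance that only a limit is reported.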

Compound 3, half-maximal cytotoxic concentration: 144000 nM
The estimate for compound 3 lay 1.7-fold (0.24 log units) above the measured number, and the stated range covers the measured number.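

In this assay, bromo in place of fluoro, on an aromatic carbon ortho to a large group, gives a 1.0-fold lower number from compound 2 to compound 3 (0.01 log units; within the scatter), so with the 2,4-difluorophenyl group present, this change leaves the read-out within normal scatter. With bromo held fixed, 2,4-difluorophenyl in place of phenyl gives an at least 2.1-fold lower number from compound 1 to compound 3 (0.32 log units; beyond the scatter), which points to that ring, rather than the 2-bromophenyl end, as the place where this small set shows a real difference in this test. From the compounds shown here alone, the size of that difference stays open-ended, as compound 1 gives no exact number: the limit of > 307000 nM in this assay, at which 1 of the 3 values shown sits.

The compounds shown leave open whether a group other than a halogen at the 2-bromophenyl position, such as a methoxy group or an amine, would shift the read-out. They also leave open whether the step between fluoro and bromo would stay this small on a plain phenyl compound.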